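This account rests on a few compounds, and the source may have more. Where it says the series, first, only, none or still open, it means among the compounds named here.

The shared core of compound 1 `C/C(=N\NC(N)=O)c1ccc2[nH]c(-c3ccc(Cl)cc3)nc2c1` and compound 2 `C/C(=N\NC(N)=O)c1ccc2c(c1)nc(-c1ccc(Cl)cc1)n2C1CCCCC1` carries a semicarbazone on one side and a 4-chlorophenyl group on the five-membered aromatic ring; the two differ only in that compound 1 has hydrogen in place of cyclohexyl on an aromatic nitrogen. In an ADME assay on Vero cells (Chlorocebus sabaeus) for cytotoxicity, read by MTT assay, with a stated time of 96 h (on this read-out higher numbers stand for lower toxicity in this test and lower numbers for higher toxicity in this test), compound 1 gives > 100000 nM, which is a limit of the test rather than a number. In this assay compound 2 likewise gives > 100000 nM, again a limit and not a number. The step from compound 2 to compound 1 is therefore a step that the two limits leave unreadable from compound 2 to compound 1, because both values sit at the limit of > 100000 nM in this assay, at which 2 of the 3 values shown sit.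

Compound 3 `C/C(=N\NC(N)=O)c1ccc2c(c1)nc(-c1ccoc1)n2C1CCCCC1` differs from compound 2 in its core by furan-3-yl in place of 4-chlorophenyl on an aromatic carbon; in this assay compound 3 gives "not determined" (no result reported), so no result for it is reported. Compound 4 `C/C(=N\NC(N)=O)c1ccc2[nH]c(-c3ccoc3)nc2c1` stands to compound 3 as compound 1 stands to compound 2, with hydrogen in place of cyclohexyl on an aromatic nitrogen. The surroundings of the place differ between the two pairs: in one the changed nitrogen lies next to the ring atom that bears a 4-chlorophenyl group, in the other next to the ring atom that bears a furan-3-yl group, so the change is the same kind of change, not the same.

Given that both measured compounds sit at the limit of > 100000 nM in this assay, at which 2 of the 3 values shown sit, the expectation for compound 4 in this assay is that it also shows no toxicity within the tested range, with an estimated value of 150000 nM between 60000 nM and 400000 nM, most likely again reported as a limit.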

Compound 4, half-maximal cytotoxic concentration: > 100000 nM
Compound 4: no number, only a limit; the forecaster's own chance of this, stated with the estimate: 85%; the middle value is on the limit's open side.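

In this assay compound 4 gives > 100000 nM, which is a limit and not a number. No size can be read for the step linking compound 1 and compound 4, because both sit at the same limit: the limit of > 100000 nM in this assay, at which 3 of the 4 values shown sit.

The compounds shown leave open how far any of them lies past that limit, and whether furan-3-yl in place of 4-chlorophenyl alters the value at all.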